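The source may report more compounds than this note shows. Statements on the series, on what has been measured and on what is new or still open speak of the compounds shown alone.

Measured in a functional assay on MDA-MB-468 cells (Homo sapiens) for antiproliferative activity, read by MTT assay, with a stated time of 72 h; on this read-out higher numbers stand for weaker inhibition and lower numbers for stronger inhibition:
Compound 1 `COc1cc(-c2nccn2C)cc(OC)c1OC`: > 100000 nM (a limit of the assay)
Compound 2 `COc1cc(-c2nccn2CC(C)C)cc(OC)c1OC`: > 100000 nM (a limit of the assay)
Compound 3 `COc1cc(-c2nccn2-c2cccc(C)c2)cc(OC)c1OC`: 22600 nM

Only compound 3 has a true number in this assay, at 22600 nM. The other results are not numbers but (the limit of > 100000 nM in this assay, at which 2 of the 3 values shown sit).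

Compound 4 `COc1cccc(-n2ccnc2-c2cc(OC)c(OC)c(OC)c2)c1` has not yet been measured. It differs from compound 3 at a single place: methoxy in place of methyl on an aromatic carbon. In words, this is methoxy in place of methyl on an aromatic carbon, turning 3-methylphenyl into 3-methoxyphenyl.

Going by the values given here, no measured step makes this exchange itself. The nearest evidence concerns the group on the aromatic nitrogen, in an at least 4.4-fold lower number from compound 1 to compound 3 (0.64 log units; beyond the scatter) and in an at least 4.4-fold lower number from compound 2 to compound 3 (0.64 log units; beyond the scatter). In both, 3-methylphenyl replaces a chain, and a measurable value appears. The remaining step, a step that the two limits leave unreadable from compound 1 to compound 2, adds nothing.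

Compound 4 keeps a substituted phenyl group on that nitrogen, so it is expected to stay close to compound 3 at 22600 nM, with no change beyond the scatter. The estimated change is a 1.1-fold lower number from compound 3 to compound 4 (0.05 log units; within the scatter). With so little evidence, the expected range is wide. For compound 4 the estimated value is 20000 nM, expected to fall between 7000 nM and 60000 nM.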

Compound 4, half-maximal inhibitory concentration: 10400 nM
Compound 4: middle estimate off by 1.9-fold (0.28 log units), on the high side, within the range that was stated.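

Exchanging methyl for methoxy on the phenyl ring gives a 2.2-fold lower number from compound 3 to compound 4 (0.34 log units; beyond the scatter), which shows that in this assay the result depends on what that ring carries and not only on the ring being there. Setting 3-methoxyphenyl in place of the groups on the aromatic nitrogen gives an at least 9.6-fold lower number from compound 2 to compound 4 (0.98 log units; beyond the scatter) and an at least 9.6-fold lower number from compound 1 to compound 4 (0.98 log units; beyond the scatter), which confirms that compounds with a substituted phenyl group at this nitrogen give true numbers while those with isobutyl or methyl do not. These last two steps are minimum sizes, not exact ones, since neither compound 1 nor compound 2 has a true number: the limit of > 100000 nM in this assay, at which 2 of the 4 values shown sit.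

With only methyl and methoxy shown on this ring, it remains open whether a hydroxyl, a chlorine or a dimethylamino group at the same place would lower the number further or raise it again. As far as these compounds go, it is also open whether methoxy would give a similar step on another carbon of the ring, or whether the step would hold with a different group on the shared core.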